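Iodo gives way to nitro on the aryl ring

The source may report more compounds than this note shows. Statements on the series, on what has been measured and on what is new or still open speak of the compounds shown alone.

Measured so far:
compound 1, `Ic1ccccc1C1=NC(c2ccccc2)CO1`, 3.86 
compound 2, `Clc1ccc(Cl)c(C2=NC(c3ccccc3)CO2)c1`, 4.4 
compound 3, `Cc1cccc(C)c1-c1ncco1`, 2.21 

In a physicochemical assay for lipophilicity (on this read-out lower numbers stand for lower lipophilicity and higher numbers for higher lipophilicity), compound 1 gives 3.86, which is the second highest of the three numbers. Its nearest neighbour is compound 2, whose value in this assay is 4.4, a difference beyond the scatter. Furthest away is compound 3, which in this assay gives 2.21, again beyond the scatter. Compound 3 also carries a different core, so its gap to compound 1 says little about a single group.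

The next compound, compound 4, is `O=[N+]([O-])c1ccccc1C1=NC(c2ccccc2)CO1`. It differs from compound 1 in one place: nitro in place of iodo on an aromatic carbon. Among the compounds with values here, no measured pair in this set changes only this group, so the expected step cannot be read off the data. Still, swapping a single iodine for a nitro group is expected to lower the number in this assay by a step clearly beyond the scatter. The estimated step is a number 1.31 log units lower from compound 1 to compound 4 (beyond the scatter). Compound 4 is therefore expected to give about 2.55, within a range from 2 to 3.1.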

Compound 4, partition coefficient: 2.83
Compound 4: middle estimate off by 0.28 log units, on the low side; the range from low to high includes it.
By their numbers in this assay, from the lowest: compound 3; then compound 4; then compound 1; then compound 2.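

Within the data shown here, this is the first pair here that differs in one place, so the effect of one group can be read directly: in this assay, nitro in place of iodo on an aromatic carbon, ortho to a large group, gives a step of a number 1.03 log units lower from compound 1 to compound 4 (beyond the scatter) with the rest of the molecule unchanged. Size alone does not set the direction in this pair, since the entering group has 3 heavy atoms and 2 hydrogen-bond acceptors, against 1 heavy atom and 0 hydrogen-bond acceptors for the group that leaves, yet the number falls. Nothing measured here explains why the step has this size.

The compounds shown leave open where an amine, a nitrile or a methoxy group would fall at this position. They also leave open whether the same swap gives a similar step at another place on the ring or on another core.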